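This account rests on a few compounds, and the source may have more. Where it says the series, first, only, none or still open, it means among the compounds named here.

Measured so far in an ADME assay on BJ cells (Homo sapiens) for cytotoxicity, read by luminescence, with a stated time of 72 h; a lower number here means that less compound is needed, a higher number that more compound is needed for the effect:

Compound 1 `CCOC(=O)c1c(-c2cccc(OCC)c2)[nH]c2cc(OC)ccc2c1=O` gives only a limit, > 21500 nM.
Compound 2 `CCOC(=O)c1c(-c2cccc(OC(C)C)c2)[nH]c2cc(OC)ccc2c1=O` gives only a limit, > 21500 nM.
Compound 3 `CCOC(=O)c1c(-c2cccc(F)c2)[nH]c2cc(OC)ccc2c1=O` gives only a limit, > 21500 nM.

Compound 1 therefore stands at the limit of this assay with no number of its own; the same holds for the other two, as the limit of > 21500 nM in this assay, at which 3 of the 3 values shown sit, records. The steps in the series are unreadable for that reason: a step that the two limits leave unreadable from compound 1 to compound 2, a step that the two limits leave unreadable from compound 1 to compound 3 and a step that the two limits leave unreadable from compound 2 to compound 3, none of which yields a size or a direction. Across an ethoxy, an isopropoxy and a fluoro group on the pendant ring the series has not yet produced a number.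

Compound 4 `CCOC(=O)c1c(-c2cccc(N(C)C)c2)[nH]c2cc(OC)ccc2c1=O` is the next member. Its change from compound 1 is dimethylamino in place of ethoxy on an aromatic carbon. Going by the values given here, no measured step bears on it, since every step is unreadable; nothing in the three values speaks for a move away from the limit. Compound 4 is therefore expected to sit at the limit again, with an estimate of 30000 nM and a range from 15000 nM to 100000 nM. The expected step that the limit leaves unreadable from compound 1 to compound 4 is accordingly estimated as none beyond the scatter.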

Compound 4, half-maximal effective concentration: > 21500 nM
Compound 4: a limit, no number; the forecaster's own chance of this, stated with the estimate: 85%; the middle value does not contradict the limit.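

No step can be read from compound 4 to compound 1, compound 2 or compound 3, since all four give only a limit: the limit of > 21500 nM in this assay, at which 4 of the 4 values shown sit.

The compounds shown leave open where each true value lies and whether any group at this place on the ring yields a measurable number.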